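Removing the chloro group from compound 2

The source may hold more compounds than are shown below. What is called first, only, known or untested is meant among the compounds shown, and "the series" means these compounds.

Measured in a functional assay on thoracic aorta (Rattus norvegicus, strain Wistar), with a stated time of 15 min; on this read-out higher numbers stand for an effect only at larger amounts of compound and lower numbers for an effect already at smaller amounts:
Compound 1 `CC(NC(=O)NS(=O)(=O)c1ccc(Cl)cc1)c1cc(Br)ccc1OCc1ccccc1`: 57500 nM
Compound 2 `CC(NC(=O)NS(=O)(=O)c1ccc(Cl)cc1)c1ccccc1OCc1ccccc1`: 157000 nM
Compound 3 `CC(NC(=O)N(C)S(=O)(=O)c1ccc(Cl)cc1)c1ccccc1OCc1ccccc1`: 38400 nM

Compound 2, at 157000 nM, has the highest number of the three, so it needs the largest amount of compound to reach its half-maximal effect. Both measured steps that touch it lie beyond the usual scatter. The next compound to be tested is compound 4 `CC(NC(=O)NS(=O)(=O)c1ccccc1)c1ccccc1OCc1ccccc1`, and it differs from compound 2 in one place: hydrogen in place of chloro on an aromatic carbon. The chloro group leaves an aromatic carbon, para to a large group, and a hydrogen takes its place.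

For the measured compounds named here, the closest precedent is also the loss of a halogen from an aromatic carbon, although at a different place in the molecule. Swapping bromo for hydrogen gave a 2.7-fold higher number from compound 1 to compound 2 (0.44 log units; beyond the scatter). The other measured step, a 4.1-fold lower number from compound 2 to compound 3 (0.61 log units; beyond the scatter), adds a methyl on nitrogen and is a different kind of change, so it says little here. Going by the values given here, no measured pair shows the loss of this chloro group itself, which leaves the direction tentative. A modest rise is the best guess, and the estimate is a 1.7-fold higher number from compound 2 to compound 4 (0.22 log units; within the scatter). Compound 4 is expected near 260000 nM, with an estimated range of 100000 nM to 650000 nM.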

Compound 4, half-maximal effective concentration: > 200000 nM
Compound 4 was reported as a limit; the forecaster's own chance of this, stated with the estimate: 25%; the middle value is on the limit's open side.
By their numbers in this assay, from the lowest: compounds 3 and 1 (each within the scatter of the next); then compound 2. At a limit, above all of these: compound 4.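

In this assay, compound 4 is reported only as a limit, not as a number: the limit of > 200000 nM in this assay, at which 1 of the 4 values shown sits. Replacing the chloro group of the 4-chlorophenyl ring with hydrogen gives an at least 1.2-fold higher number from compound 2 to compound 4 (0.10 log units; that floor lies within the scatter), and only this floor can be read, so the true step may be small or much larger. For the compounds shown here, this is the first view of the aromatic carbon that carries the chloro group, as the earlier steps changed a bromo group and an amide-type nitrogen elsewhere in the molecule, and it shows that the phenylsulfonyl compound gives no lower number than the (4-chlorophenyl)sulfonyl compound.

The compounds shown leave open how far the number really rises when the chloro group goes, and so whether this step is larger or smaller than a 2.7-fold higher number from compound 1 to compound 2 (0.44 log units; beyond the scatter). Also open, as far as these compounds go, is whether a different group on this carbon, such as methoxy, an amine or a carboxylic acid, would bring the number down, and whether a methyl on the amide-type nitrogen would lower the number of compound 4 as it does in a 4.1-fold lower number from compound 2 to compound 3 (0.61 log units; beyond the scatter).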